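Tetrazole for Nitrile on the Side Chain of Compound 1

The source may report more compounds than this note shows. Statements on the series, on what has been measured and on what is new or still open speak of the compounds shown alone.

Compound 1 `CCc1cc(C(C)=O)c(O)cc1OCCCCCCC#N` gives 103%
Compound 2 `C=CCc1cc(C(C)=O)c(O)cc1OCCCCCCC#N` gives 97%

For the measured compounds named here, in an assay on isolated protein for inhibition of leukotriene B4 receptor 1 (Homo sapiens), tested at 10 uM (a lower number here means less inhibition, a higher number more inhibition at the concentration tested (going by the name of the read-out)), compound 1 gives 103%, the higher of the two numbers; the only other measured number is a number 6 percentage points lower from compound 1 to compound 2 (within the scatter). Compound 3 `CCc1cc(C(C)=O)c(O)cc1OCCCC(C)(C)c1nnn[nH]1` differs from compound 1 by 1-(1H-tetrazol-5-yl)-1-methylethyl in place of 3-cyanopropyl on a saturated chain carbon, three bonds along the chain from an oxygen on an aromatic ring. Going by the values given here, the single measured step concerns the carbon bound to the aromatic ring, not this chain, so no measured step bears on the change, and the number of compound 1 in this assay is high. Compound 3 is therefore expected to remain near that level, a number 8 percentage points lower from compound 1 to compound 3 (within the scatter), with an estimate of 95% and a range from 70% to 105%.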

Compound 3, a percentage reported as inhibition, at one concentration (the size of the read-out at that concentration, not a potency): 100%
Beside the measured number, compound 3's estimate is 5 percentage points below it; low and high end bracket the measured number.
By their numbers in this assay, from the lowest: compounds 2, 3 and 1 (each within the scatter of the next).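

In this assay the change reads as a number 3 percentage points lower from compound 1 to compound 3 (within the scatter) and shows that this position, on a saturated chain carbon, three bonds along the chain from an oxygen on an aromatic ring, accepts 1-(1H-tetrazol-5-yl)-1-methylethyl in place of 3-cyanopropyl without a change beyond the scatter. The read-out comes from one concentration, so it does not compare potency. Nothing measured here accounts for this result. Open, going by these compounds, is whether a carboxylic acid or an amine at this place would give a similar number, and whether a longer chain would.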